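Replacing Hydroxy with Dimethylamino on a Shared Core

The source may report more compounds than this note shows. Statements on the series, on what has been measured and on what is new or still open speak of the compounds shown alone.

Compound 1 `COc1ccc(C2C(C)C(=O)CC(c3ccc(Cl)cc3)N2C(=O)CCl)cc1`: 1.29
Compound 2 `CC1C(=O)CC(c2ccc(Cl)cc2)N(C(=O)CCl)C1c1ccc(O)cc1`: 1.05
Compound 3 `CC1C(=O)CC(c2ccc(F)cc2)N(C(=O)CCl)C1c1ccc(O)cc1`: 1.14

In a physicochemical assay for lipophilicity, using the shake flask method (on this read-out lower numbers stand for lower lipophilicity and higher numbers for higher lipophilicity), compound 2 gives 1.05, and the two other measured compounds sit within the scatter of it: a number 0.24 log units lower from compound 1 to compound 2 (within the scatter) and a number 0.09 log units higher from compound 2 to compound 3 (within the scatter). Compound 4 `CC1C(=O)CC(c2ccc(Cl)cc2)N(C(=O)CCl)C1c1ccc(N(C)C)cc1` differs from compound 2 in one place, (dimethylamino in place of hydroxy on an aromatic carbon). Within the data shown here, no measured step covers this exchange; the only step at the same place is a number 0.24 log units lower from compound 1 to compound 2 (within the scatter), which stays within the scatter, and the step from compound 2 to compound 3 concerns a different ring. The expectation therefore rests on the counted difference alone, and a rise beyond the scatter is expected, a number 0.70 log units higher from compound 2 to compound 4 (beyond the scatter). Compound 4 is estimated at 1.75, with a range from 1.3 to 2.2.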

Compound 4, partition coefficient: 1.24
Compound 4: the middle estimate sits 0.51 log units above what was measured, outside the stated range (below it).
By their numbers in this assay, from the lowest: compounds 2, 3, 4 and 1 (each within the scatter of the next).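

In this assay, the change from 4-hydroxyphenyl to 4-(dimethylamino)phenyl, on an aromatic carbon para to a large group, gives a number 0.19 log units higher from compound 2 to compound 4 (within the scatter) even though dimethylamino brings more heavy atoms and no hydrogen-bond donor. The exchange of methoxy for dimethylamino at the same place gives a number 0.05 log units lower from compound 1 to compound 4 (within the scatter) and so hydroxy, methoxy and dimethylamino all read alike here. No measurement on hand accounts for this. Going by these compounds, it remains open whether a carboxylic acid or a primary amine at this position would also stay within the scatter. On these data alone, whether dimethylamino would read the same on compound 3, which carries fluoro in place of chloro, is also open.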